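The source may report more compounds than this note shows. Statements on the series, on what has been measured and on what is new or still open speak of the compounds shown alone.

Compound 1, `O=C1/C(=C/c2ccc(F)cc2)Cc2ccccc21`, is a bare starting point: in a functional assay on P388 cells (Mus musculus) for inhibition (a lower number here means a stronger inhibitor, a higher number a weaker inhibitor), compound 1 gives only > 50000 nM, which is a limit of the assay rather than a number. Compound 2, `O=C1/C(=C/c2ccc(Cl)cc2)Cc2ccccc21`, carries the change (chloro in place of fluoro on an aromatic carbon). In this assay compound 2 likewise gives > 50000 nM, again a limit. The step that the two limits leave unreadable from compound 1 to compound 2 therefore cannot be sized, because both of its ends sit at the limit of > 50000 nM in this assay, at which 2 of the 3 values shown sit.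

Compound 3, `O=C1/C(=C/c2ccc(F)cc2)CCCc2ccccc21`, has a different core; how its core differs from that of compound 1 is not broken down here. In this assay compound 3 gives 11100 nM, the only true number among these three.

Compound 4, `O=C1/C(=C/c2ccc(Cl)cc2)CCCc2ccccc21`, is not yet measured. It differs from compound 3 by chloro in place of fluoro on an aromatic carbon, the same change as from compound 1 to compound 2. Since that earlier step left no readable size, the expectation for compound 4 rests on compound 3 alone: a step of about a 1.0-fold lower number from compound 3 to compound 4 (0.00 log units; within the scatter) is expected, within the usual scatter. Compound 4 is thus estimated at 11000 nM in this assay, between 4000 nM and 30000 nM.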

Compound 4, half-maximal inhibitory concentration: 9500 nM
The estimate for compound 4 lay 1.2-fold (0.06 log units) above the measured number; measured number inside the range.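

On the core of compound 3, chloro in place of fluoro gives a 1.2-fold lower number from compound 3 to compound 4 (0.07 log units; within the scatter) in this assay, so on this core the two compounds cannot be told apart. The same change on the core of compound 1 cannot be read, because both ends of that step sit at a limit of the assay: the limit of > 50000 nM in this assay, at which 2 of the 4 values shown sit. This leaves a single readable case of the change, so it does not show that the change behaves alike on both cores, nor that it behaves differently.

Among the compounds shown, this place on the aromatic ring holds only fluoro or chloro, so it stays open whether another group there, such as an amine or a carboxylic acid, would shift the number beyond the scatter. On these data alone, it also stays open whether any such group would bring the core of compound 1 to a true number in this assay.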